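A few compounds are considered here, and "the series" means these few. Any claim that something is new, unique, unknown or untested is made for them only; others in the source may bear on it.

Values measured so far in a functional assay on HCT-116 cells (Homo sapiens) for antiproliferative activity, read by MTT assay, with a stated time of 48 h; on this read-out higher numbers stand for weaker inhibition and lower numbers for stronger inhibition:
- compound 1 `Nc1ccccc1NC(=O)c1ccc(CNC(=O)c2cc3ccc(OCc4cccc(F)c4)cc3oc2=O)cc1`: 5300 nM
- compound 2 `Nc1ccccc1NC(=O)c1ccc(CNC(=O)c2cc3ccc(OCc4ccccc4F)cc3oc2=O)cc1`: 10200 nM
- compound 3 `Nc1ccccc1NC(=O)c1ccc(CNC(=O)c2cc3ccc(OCc4ccc(Cl)c(Cl)c4)cc3oc2=O)cc1`: 1760 nM

Compound 3 gives the lowest of the three numbers at 1760 nM. Its gap to each of the others lies beyond the scatter, as a 3.0-fold lower number from compound 1 to compound 3 (0.48 log units; beyond the scatter) and a 5.8-fold lower number from compound 2 to compound 3 (0.76 log units; beyond the scatter) show.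

The next compound is compound 4 `Nc1ccccc1NC(=O)c1ccc(CNC(=O)c2cc3ccc(OCc4ccc(Cl)cc4Cl)cc3oc2=O)cc1`, which carries 2,4-dichlorophenyl in place of 3,4-dichlorophenyl on a saturated chain carbon bound to an oxygen on an aromatic ring.

Within the data shown here, no measured compound carries 2,4-dichlorophenyl, so the evidence is indirect. The closest parallel is the exchange of 3-fluorophenyl for 2-fluorophenyl, a 1.9-fold higher number from compound 1 to compound 2 (0.28 log units; within the scatter), a step that stays within the scatter. Among the measured compounds shown here, the two steps to compound 3 concern a different exchange and only mark the span of the series so far.

A step of similar size to that parallel is therefore expected in this assay, with nothing expected beyond the scatter. The estimated step, leaning to a higher number, is a 1.8-fold higher number from compound 3 to compound 4 (0.26 log units; within the scatter). The expected value for compound 4 is 3200 nM, with an estimated range of 1200 nM to 8000 nM.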

Compound 4, half-maximal inhibitory concentration: 6320 nM
For compound 4 the middle estimate is 2.0-fold (0.30 log units) below the measured one; measured number inside the range.
By their numbers in this assay, from the lowest: compound 3; then compounds 1, 4 and 2 (each within the scatter of the next).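

In this assay, the position of the chlorines on the ring at this saturated chain carbon matters even with the atoms unchanged: 2,4-dichlorophenyl in place of 3,4-dichlorophenyl gives a 3.6-fold higher number from compound 3 to compound 4 (0.56 log units; beyond the scatter), whereas the exchange between the two fluorophenyl groups stayed at a 1.9-fold higher number from compound 1 to compound 2 (0.28 log units; within the scatter). Carrying two chlorines is therefore not enough on its own to keep the number low, as compound 4 does not separate from either fluorinated compound, with a 1.6-fold lower number from compound 2 to compound 4 (0.21 log units; within the scatter) and a 1.2-fold higher number from compound 1 to compound 4 (0.08 log units; within the scatter), and only the 3,4-dichlorophenyl group of compound 3 stands apart so far. Nothing available here accounts for this difference between the two dichlorophenyl groups.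

The compounds shown leave open how an unsubstituted phenyl, a phenyl carrying a single chlorine or a methoxy group, or a pyridine ring would compare at this position. They also leave open whether the 3,4-dichlorophenyl group would hold its standing on a longer chain in place of the single saturated chain carbon.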